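A few compounds are considered here, and "the series" means these few. Any claim that something is new, unique, unknown or untested is made for them only; others in the source may bear on it.

Of the compounds shown here, two of one shared core have been tested so far. Compound 1 `CC(C)n1nc(-c2ccccc2)c(-c2ccccc2)cc1=O` carries its two phenyl groups on a ring with a carbonyl, and in an assay on microsomes from liver for inhibition of sterol O-acyltransferase 1 (Rattus norvegicus) (on this read-out higher numbers stand for weaker inhibition and lower numbers for stronger inhibition), compound 1 gives 152000 nM. Compound 2 `CCCCCCCCCSc1cc(-c2ccccc2)c(-c2ccccc2)nn1` carries a nonyl chain on a sulfur attached to the core, and in this assay compound 2 gives 116000 nM. These two numbers lie within the usual scatter of each other, so compound 2 and compound 1 stand close together, both far from strong inhibition.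

Compound 3 `O=C(O)CCCCCCCSc1cc(-c2ccccc2)c(-c2ccccc2)nn1` differs from compound 2 in one place: carboxy in place of ethyl on a saturated chain carbon, seven bonds along the chain from a sulfur. Among the compounds with values here, no measured pair shows what such a change does here, so nothing beyond the scatter is expected in either direction. The step from compound 2 to compound 3 in this assay is estimated as a 1.1-fold higher number from compound 2 to compound 3 (0.05 log units; within the scatter). Compound 3 is therefore expected to give about 130000 nM, with a range from 40000 nM to 400000 nM.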

Compound 3, half-maximal inhibitory concentration: > 300000 nM
Compound 3 was reported as a limit (the forecaster's own chance of this, stated with the estimate: 30%); at least 2.3-fold (0.36 log units) between middle value and limit.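

Carboxy in place of ethyl on a saturated chain carbon, seven bonds along the chain from a sulfur, gives an at least 2.5-fold higher number from compound 2 to compound 3 (0.41 log units; beyond the scatter), so the group carried on this chain does matter for inhibition in this assay. Within the data shown here, the earlier compounds offered no change in a single place, and this pair is the first to show a step beyond the scatter, in the direction of weaker inhibition. The reading for compound 3 is a limit and not a number, so the step has a lower bound but no known full size: the limit of > 300000 nM in this assay, at which 1 of the 3 values shown sits.

This single pair cannot tell whether the weakening belongs to the carboxy group alone or would also come with other groups at that place, such as an alcohol, an ester or an amine. As far as these compounds go, how a shorter or longer chain carrying the carboxy group would read also stays open.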